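Thiophen-2-yl for furan-2-yl in compound 2

The source may hold more compounds than are shown below. What is called first, only, known or untested is meant among the compounds shown, and "the series" means these compounds.

In an ADME assay on cells (Hepatocyte, Homo sapiens) for metabolic stability (a higher number here means that the compound lasts longer, a lower number that the compound disappears faster), compound 2 `O=C(OC1CCC(CN2CCN(c3cc(=O)c4cc(C(F)(F)F)cc([N+](=O)[O-])c4s3)CC2)CC1)c1ccco1` gives 0.075 h and compound 3 `O=C(OC1CCC(CN2CCN(c3cc(=O)c4cc(C(F)(F)F)cc([N+](=O)[O-])c4s3)CC2)CC1)C1CCCCC1` gives 0.0967 h, two numbers within the scatter of each other. Compound 1 `CS(=O)(=O)NC1CCC(CN2CCN(c3cc(=O)c4cc(C(F)(F)F)cc([N+](=O)[O-])c4s3)CC2)CC1` is recorded only as a limit, > 1.55 h.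

Two large steps, an at least 20-fold lower number from compound 1 to compound 2 (1.31 log units; beyond the scatter) and an at least 16-fold lower number from compound 1 to compound 3 (1.20 log units; beyond the scatter), replace methanesulfonamido on a saturated ring carbon, so they say little about the present change. The step that bears on it is a 1.3-fold higher number from compound 2 to compound 3 (0.11 log units; within the scatter), with cyclohexyl in place of furan-2-yl on a carbonyl carbon.

Compound 4 `O=C(OC1CCC(CN2CCN(c3cc(=O)c4cc(C(F)(F)F)cc([N+](=O)[O-])c4s3)CC2)CC1)c1cccs1` changes that same place, with thiophen-2-yl in place of furan-2-yl on a carbonyl carbon. No step beyond the scatter is expected in this assay, given compound 3 at 0.0967 h. The expected size is a 1.1-fold higher number from compound 2 to compound 4 (0.05 log units; within the scatter), within the scatter. For compound 4 the estimate is 0.085 h, with an expected range from 0.045 h to 0.17 h.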

Compound 4, half-life: 0.0917 h
Estimate against measurement, compound 4: 1.1-fold (0.03 log units) below, and the stated range covers the measured number.
By their numbers in this assay, from the lowest: compounds 2, 4 and 3 (each within the scatter of the next). At a limit, above all of these: compound 1.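

On the carbonyl carbon, furan-2-yl, thiophen-2-yl and cyclohexyl now give numbers within the scatter of one another in this assay: a 1.2-fold higher number from compound 2 to compound 4 (0.09 log units; within the scatter), and a 1.1-fold lower number from compound 3 to compound 4 (0.02 log units; within the scatter). Sulfur in place of oxygen in the five-membered aromatic ring, with the heavy-atom count unchanged, therefore gives no readable change at this position, and a second aromatic ring joins the earlier comparison with a saturated one. The large step away from methanesulfonamido now holds for a third ester, an at least 16-fold lower number from compound 1 to compound 4 (1.22 log units; beyond the scatter), and its full size cannot be read: the limit of > 1.55 h in this assay, at which 1 of the 4 values shown sits.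

Still open, on these data alone, is whether an amine or a carboxylic acid on the carbonyl carbon would give a number beyond the scatter of these three esters. An amide in place of the ester oxygen would show whether that single atom carries the large step from compound 1.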